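Swapping the Hydroxy of Compound 3 for Fluoro

A few compounds are considered here, and "the series" means these few. Any claim that something is new, unique, unknown or untested is made for them only; others in the source may bear on it.

Compound 3 `CC1(C)CCC(C)(C)c2cc(C(=O)c3ccc4cc(C(=O)O)ccc4c3)c(O)cc21` has the second highest of three numbers in an assay on isolated protein with retinoic acid receptor gamma (Homo sapiens) as the target; a higher number here means a larger maximal response, a lower number a smaller maximal response: compound 3 gives 70%, compound 1 `CC1(C)CCC(C)(C)c2c1cc(O)c(C(=O)c1ccc3cc(C(=O)O)ccc3c1)c2F` gives 92% and compound 2 `COc1c(C(=O)c2ccc3cc(C(=O)O)ccc3c2)ccc2c1C(C)(C)CCC2(C)C` gives 0%. Among the compounds with values here, the only measured step between neighbours, a number 22 percentage points lower from compound 1 to compound 3 (beyond the scatter), is a change elsewhere on the core and does not touch the hydroxy. Compound 4 `CC1(C)CCC(C)(C)c2cc(C(=O)c3ccc4cc(C(=O)O)ccc4c3)c(F)cc21` differs from compound 3 by fluoro in place of hydroxy on an aromatic carbon. Within the data shown here, no measured step removes a hydroxy, so the expectation rests only on compound 2, which carries a methoxy in place of a hydroxy and shows no response. A clear fall is therefore expected, with the estimate for compound 4 at 30% between 0% and 70%, meaning an expected step of a number 40 percentage points lower from compound 3 to compound 4 (beyond the scatter).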

Compound 4, largest response reached (reported as maximum), in percent of the reference or control that the assay uses: 70%
Estimate against measurement, compound 4: 40 percentage points below, and the stated range covers the measured number.
By their numbers in this assay, from the lowest: compound 2; then compounds 3 and 4 (each within the scatter of the next); then compound 1.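

In this assay, placing fluoro instead of hydroxy on this aromatic carbon, ortho to a large group, gives no change at the digits printed from compound 3 to compound 4 (within the scatter). On this core, then, the maximal response does not require a hydroxy here, even though fluoro counts no hydrogen-bond donor or acceptor. No supporting measurement explains why these two groups give matching responses.

On these data alone, whether the response would also hold with an amine or a methyl group at this position remains open. So does whether this match would persist on a core carrying other changes.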